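Closing an Open Chain into a Carboxamide Piperidine

The source may report more compounds than this note shows. Statements on the series, on what has been measured and on what is new or still open speak of the compounds shown alone.

Of the compounds shown here, three built on one shared core have been measured in an assay on HEK293 cells for displacement of a labelled ligand from NPC1-like intracellular cholesterol transporter 1 (Homo sapiens); on this read-out lower numbers stand for stronger inhibition and higher numbers for weaker inhibition. Compound 1 `CCOC(=O)C1CCN(C(=O)CN2CN(c3ccccc3)C3(CCN(C(=O)c4ccc(C5CCCCC5)cc4)CC3)C2=O)CC1` gives 900 nM in this assay. Compound 2 `CC(C)(C)OC(=O)NCCNC(=O)CN1CN(c2ccccc2)C2(CCN(C(=O)c3ccc(C4CCCCC4)cc3)CC2)C1=O` gives 5500 nM. Compound 3 `CC(C)(C)c1ccc(C(=O)N2CCC3(CC2)C(=O)N(CC(=O)NCCCN)CN3c2ccccc2)cc1` gives 4200 nM; among the three numbers it stands second highest, within the scatter of compound 2 and beyond the scatter above compound 1. Compound 4 `CC(C)(C)c1ccc(C(=O)N2CCC3(CC2)C(=O)N(CC(=O)N2CCCC(C(N)=O)C2)CN3c2ccccc2)cc1` has not yet been measured. It differs from compound 3 at one place: 3-carbamoylpiperidin-1-yl in place of (3-aminopropyl)amino on a carbonyl carbon.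

Within the data shown here, one measured step bears on this change, though it runs the other way. Putting (2-((tert-butoxycarbonyl)amino)ethyl)amino in place of 4-(ethoxycarbonyl)piperidin-1-yl on a carbonyl carbon gave a 6.1-fold higher number from compound 1 to compound 2 (0.79 log units; beyond the scatter). The move from compound 3 to compound 4 instead closes an open chain into a piperidin-1-yl group on a carbonyl carbon, so a lower number, beyond the scatter, is expected, with the caution that the groups themselves are not the same ones. The step is estimated at a 2.8-fold lower number from compound 3 to compound 4 (0.45 log units; beyond the scatter). Compound 4 is therefore expected to give about 1500 nM in this assay, with a plausible range from 500 nM to 5000 nM.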

Compound 4, half-maximal inhibitory concentration: 16900 nM
For compound 4 the middle estimate is 11-fold (1.05 log units) below the measured one; measured number above the stated range.
By their numbers in this assay, from the lowest: compound 1; then compounds 3 and 2 (each within the scatter of the next); then compound 4.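

In this assay, 3-carbamoylpiperidin-1-yl in place of the open (3-aminopropyl)amino chain gives a 4.0-fold higher number from compound 3 to compound 4 (0.60 log units; beyond the scatter), so putting this ring on the carbonyl carbon does not by itself lower the number. The earlier step, a 6.1-fold higher number from compound 1 to compound 2 (0.79 log units; beyond the scatter), went up when an open chain replaced a piperidine ring, so these two steps show no single direction for ring against open chain at this place; the groups in the two steps are different ones. Nothing available here accounts for the rise.

The compounds shown leave open whether the ring itself or its carbamoyl group goes with the higher number, which a plain piperidin-1-yl group could separate. They also leave open how a 4-carbamoylpiperidin-1-yl group or a carboxylic acid on the ring would read at this place.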